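Swapping Fluoro for Methyl in a Weakly Antiproliferative Series

This account rests on a few compounds, and the source may have more. Where it says the series, first, only, none or still open, it means among the compounds named here.

Compound 1 `Cc1nn2c(-c3nc4cc(C(F)(F)F)ccc4[nH]3)c(-c3ccc(F)cc3)nc2s1`: 15800 nM
Compound 2 `Cc1ccc2[nH]c(-c3c(-c4ccc(F)cc4)nc4sc(C)nn34)nc2c1`: 19900 nM
Compound 3 `Cc1nn2c(-c3nc4ccccc4[nH]3)c(-c3ccc(F)cc3)nc2s1`: > 30000 nM

Among the measured compounds shown here, in a functional assay on DU-145 cells (Homo sapiens) for antiproliferative activity, read by MTT assay (on this read-out higher numbers stand for weaker inhibition and lower numbers for stronger inhibition), compound 2 gives 19900 nM, one of only two true numbers in this set. The step between those two numbers reads a 1.3-fold higher number from compound 1 to compound 2 (0.10 log units; within the scatter). Compound 3 gives > 30000 nM, which is a limit of the assay and not a number. Also worth keeping in view is the limit of > 30000 nM in this assay, at which 1 of the 3 values shown sits.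

Compound 4 `Cc1ccc(-c2nc3sc(C)nn3c2-c2nc3cc(C)ccc3[nH]2)cc1` is compound 2 with one group exchanged: methyl in place of fluoro on an aromatic carbon. This is methyl in place of fluoro on an aromatic carbon, turning 4-fluorophenyl to 4-methylphenyl.

For the measured compounds named here, no measured step touches that group. The nearest guides are swaps among trifluoromethyl, methyl and hydrogen at another place in the molecule: an at least 1.8-fold higher number from compound 1 to compound 3 (0.27 log units; that floor lies within the scatter) and an at least 1.5-fold higher number from compound 2 to compound 3 (0.17 log units; that floor lies within the scatter), along with the step already given. None of them shows a change beyond the scatter, so they offer only weak guidance, and no direction can be drawn from them. A step beyond the scatter is therefore not expected in this assay. The expected step reads a 1.0-fold lower number from compound 2 to compound 4 (0.02 log units; within the scatter). The estimate for compound 4 is 19000 nM, with an expected range from 9000 nM to 30000 nM.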

Compound 4, half-maximal inhibitory concentration: 10700 nM
Compound 4: middle estimate off by 1.8-fold (0.25 log units), on the high side; the range from low to high includes it.
By their numbers in this assay, from the lowest: compounds 4, 1 and 2 (each within the scatter of the next). At a limit, above all of these: compound 3.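

Among the compounds shown here, until now every measured step concerned another place in the molecule, so a 1.9-fold lower number from compound 2 to compound 4 (0.27 log units; within the scatter) is the first reading in this assay of a change on the six-membered aromatic ring of carbon only, para to a large group. Because that step lies within the scatter, the two compounds cannot be told apart here, and in this pair methyl stands in for fluoro with no loss of activity beyond the scatter. The swap exchanges one heavy atom for one heavy atom and adds no hydrogen-bond donor or acceptor, and nothing measured here explains any part of the step, so this single pair shows only that the position accepts either group.

From the compounds shown here alone, what an amine, a carboxylic acid or a longer chain would do in the same place remains open, as does whether any group there can give a step beyond the scatter. Also open is whether changes at this position can take the series well clear of the top of the measurable range, where one compound still stands as a limit: the limit of > 30000 nM in this assay, at which 1 of the 4 values shown sits.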